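Swapping a Dichlorophenyl Urea for a Trifluoromethylphenyl Urea

The source may report more compounds than this note shows. Statements on the series, on what has been measured and on what is new or still open speak of the compounds shown alone.

In a functional assay on SK-MEL-2 cells (Homo sapiens) for inhibition, read by sulforhodamine B assay, with a stated time of 48 h, tested at 10 uM (on this read-out higher numbers stand for a weaker effect at the one concentration tested and lower numbers for a stronger effect), compound 3 `COc1cc(Cl)cc(-c2nn(-c3cccc(NC(=O)Nc4ccc(Cl)c(Cl)c4)c3)cc2-c2ccncc2)c1` gives -32.1%, the second highest of three numbers. Its nearest neighbour is compound 2 `COc1cc(Cl)cc(-c2nn(-c3cccc(NC(=O)Nc4ccc(Cl)c(C(F)(F)F)c4)c3)cc2-c2ccncc2)c1`, which gives -34%, while compound 1 `COc1cc(Cl)cc(-c2nn(-c3cccc(NC(=O)c4ccc(Cl)c(Cl)c4)c3)cc2-c2ccncc2)c1` gives 78.4%. The step of a number 1.9 percentage points higher from compound 2 to compound 3 (within the scatter) stayed within the scatter, whereas a number 112.4 percentage points lower from compound 1 to compound 2 (beyond the scatter) and a number 110.5 percentage points lower from compound 1 to compound 3 (beyond the scatter) were large. Compound 4 `COc1cc(Cl)cc(-c2nn(-c3cccc(NC(=O)Nc4cccc(C(F)(F)F)c4)c3)cc2-c2ccncc2)c1` differs from compound 3 by 3-(trifluoromethyl)phenyl in place of 3,4-dichlorophenyl on an amide-type nitrogen. Among the measured compounds shown here, the only measured step that bears on this change, a number 1.9 percentage points higher from compound 2 to compound 3 (within the scatter), lay within the scatter, so no step beyond the scatter is expected here either, although the loss of one chloro group has no measured counterpart. Compound 4 is therefore estimated at -20%, within -55% to 25%, an expected step of a number 12.1 percentage points higher from compound 3 to compound 4 (beyond the scatter).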

Compound 4, a percentage reported as activity, at one concentration (the size of the read-out at that concentration, not a potency): -36.7%
Estimate against measurement, compound 4: 16.7 percentage points above, within the range that was stated.
By their numbers in this assay, from the lowest: compounds 4, 2 and 3 (each within the scatter of the next); then compound 1.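

In this assay, the aryl group on the amide-type nitrogen tolerates more than one swap: 3-(trifluoromethyl)phenyl in place of 3,4-dichlorophenyl gives a number 4.6 percentage points lower from compound 3 to compound 4 (within the scatter), and hydrogen in place of chloro on the aromatic carbon gives a number 2.7 percentage points lower from compound 2 to compound 4 (within the scatter). With only one substituent left on this ring, the urea still stands far from the amide, with (3-(trifluoromethyl)phenyl)amino in place of 3,4-dichlorophenyl on the carbonyl carbon giving a number 115.1 percentage points lower from compound 1 to compound 4 (beyond the scatter). Nothing available explains these results. As far as these compounds go, whether an amine or a carboxylic acid on this ring would keep the same effect remains open.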